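The source may hold more compounds than are shown below. What is called first, only, known or untested is meant among the compounds shown, and "the series" means these compounds.

The measured compounds:
Compound 1, `COc1ccc(-c2cn(Cc3ccccc3)nn2)cc1`. In a functional assay on HL-60 cells (Homo sapiens) for antiproliferative activity, read by MTT assay, with a stated time of 72 h (on this read-out higher numbers stand for weaker inhibition and lower numbers for stronger inhibition), compound 1 gives > 100000 nM, which is a limit of the assay and not a number.
Compound 2, `FC(F)(F)c1ccc(-c2cn(Cc3ccccc3)nn2)cc1`. In this assay compound 2 gives 171000 nM.
Compound 3, `C1=C(c2cn(Cc3ccccc3)nn2)CCCC1`. In this assay compound 3 gives 171000 nM.

Compound 3 stands level with compound 2, within the scatter. Within the data shown here, the only step between measured compounds, a step that the limit leaves unreadable from compound 1 to compound 2, cannot be sized because the limit of > 100000 nM in this assay, at which 1 of the 3 values shown sits, hides its starting point.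

Compound 4, `CCCCc1cn(Cc2ccccc2)nn1`, is not yet measured. It differs from compound 3 by butyl in place of cyclohex-1-en-1-yl on an aromatic carbon. Among the measured compounds shown here, no measured step covers this kind of change, so nothing here points to a shift in either direction, and the expected step of a 1.0-fold lower number from compound 3 to compound 4 (0.00 log units; within the scatter) is estimated to stay within the scatter. For compound 4 the estimate in this assay is 170000 nM, expected between 60000 nM and 500000 nM.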

Compound 4, half-maximal inhibitory concentration: > 100000 nM
Compound 4 was reported as a limit; the forecaster's own chance of this, stated with the estimate: 30%; the middle value does not contradict the limit.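

In this assay compound 4 gives > 100000 nM, which is a limit and not a number. The step from compound 3 to compound 4 therefore cannot be read. The compounds shown leave open how far butyl and cyclohex-1-en-1-yl lie apart in this assay.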